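The source may report more compounds than this note shows. Statements on the series, on what has been measured and on what is new or still open speak of the compounds shown alone.

Going by the values given here, compound 1 `N#Cc1ccc(Cn2cc(COc3ccc(C#N)cc3)nn2)cc1` gives 9160 nM in an assay on isolated protein for inhibition of Aromatase (Homo sapiens), read by fluorescence and colorimetric assay, with a stated time of 30 min (a higher number here means a weaker inhibitor, a lower number a stronger inhibitor), the second highest of the three numbers measured so far. Its companions differ only on the other aromatic ring: compound 2 `N#Cc1ccc(Cn2cc(COc3ccc([N+](=O)[O-])cc3)nn2)cc1` gives 5620 nM and compound 3 `N#Cc1ccc(Cn2cc(COc3ccc(-c4ccccc4)cc3)nn2)cc1` gives 11600 nM. The steps among them are modest at most: a 1.6-fold lower number from compound 1 to compound 2 (0.21 log units; within the scatter), a 1.3-fold higher number from compound 1 to compound 3 (0.10 log units; within the scatter), and a 2.1-fold higher number from compound 2 to compound 3 (0.31 log units; beyond the scatter). Compound 4 `N#Cc1ccc(OCc2cn(Cc3ccccc3)nn2)cc1` changes a different part of the molecule: hydrogen in place of cyano on an aromatic carbon. Among the compounds with values here, no measured step touches this position, so the three steps offer only the general observation that changes have moved the number little. The expected step of a 1.3-fold higher number from compound 1 to compound 4 (0.12 log units; within the scatter) is therefore small, with no clear direction. Compound 4 is estimated at 12000 nM, between 5000 nM and 30000 nM.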

Compound 4, half-maximal inhibitory concentration: 1360 nM
Estimate against measurement, compound 4: 8.8-fold (0.95 log units) above, outside the stated range (below it).
By their numbers in this assay, from the lowest: compound 4; then compounds 2, 1 and 3 (each within the scatter of the next, the first and the last beyond it).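

Replacing the cyano group with hydrogen on this ring, para to a large group, gives a 6.7-fold lower number from compound 1 to compound 4 (0.83 log units; beyond the scatter) and is a larger step than any of those seen on the other aromatic ring. So this position affects the number more than the changes made so far elsewhere, and the nitrile here is not needed for inhibition of aromatase in this series. No measurement shown explains this change.

Going by these compounds, only cyano and hydrogen are compared at this position, so it remains open how a halogen such as fluorine, a methoxy group or an amine would behave there. On these data alone, whether hydrogen gives a similar step with nitro or phenyl on the other ring also remains open.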